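Closing the Butylamino Chain into a Piperidine Ring

The source may hold more compounds than are shown below. What is called first, only, known or untested is meant among the compounds shown, and "the series" means these compounds.

Of the compounds shown here, two have been tested in a functional assay on DU-145 cells (Homo sapiens) for inhibition, read by MTT assay, with a stated time of 72 h; on this read-out lower numbers stand for stronger inhibition and higher numbers for weaker inhibition. Compound 1 `CCCNc1cc(-c2ccccc2)nc2cc(OC)cc(OC)c12` gives 9770 nM. Compound 2 `CCCCNc1cc(-c2ccccc2)nc2cc(OC)cc(OC)c12` gives 4630 nM, the lowest of the two numbers; the move between them is a 2.1-fold lower number from compound 1 to compound 2 (0.32 log units; beyond the scatter). Compound 3 `COc1cc(OC)c2c(N3CCCCC3)cc(-c3ccccc3)nc2c1` has not yet been measured. It differs from compound 2 by piperidin-1-yl in place of butylamino on an aromatic carbon, on an aromatic carbon of the shared core, opposite the ring nitrogen, so the open chain becomes a ring. Among the measured compounds shown here, only one measured step bears on this change, a 2.1-fold lower number from compound 1 to compound 2 (0.32 log units; beyond the scatter), and only loosely: it shows that a lengthened chain gave a modestly lower number, but no measured pair tests closing the chain into a ring. The expected step of a 1.1-fold higher number from compound 2 to compound 3 (0.03 log units; within the scatter) is therefore small, within the scatter, with no firm direction. Compound 3 is estimated at 5000 nM, with a range from 1500 nM to 16000 nM.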

Compound 3, half-maximal inhibitory concentration: > 100000 nM
Compound 3 ended at the assay's limit (the forecaster's own chance of this, stated with the estimate: 5%); middle value at least 20-fold (1.30 log units) from the limit.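

In this assay compound 3 stands at a limit of the assay and not at a number: the limit of > 100000 nM in this assay, at which 1 of the 3 values shown sits.

On this aromatic carbon opposite the ring nitrogen, the change from an open chain to a ring counts for far more than the chain length did: the ring gives an at least 21-fold higher number from compound 2 to compound 3 (1.33 log units; beyond the scatter) and an at least 10-fold higher number from compound 1 to compound 3 (1.01 log units; beyond the scatter), against the modest 2.1-fold lower number from compound 1 to compound 2 (0.32 log units; beyond the scatter). The position is therefore not indifferent to the form of its amine, since butylamino, with 1 hydrogen-bond donor and no ring, gives way here to piperidin-1-yl, with 0 hydrogen-bond donors and one six-membered ring.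

Those two differences travel together, so the compounds shown cannot say which one carries the step. A diethylamino group, open and without the nitrogen's hydrogen, and a cyclohexylamino group, ringed and keeping that hydrogen, would pull them apart.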